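The source may report more compounds than this note shows. Statements on the series, on what has been measured and on what is new or still open speak of the compounds shown alone.

Measured in a functional assay on HepG2 cells (Homo sapiens) for cytotoxicity, read by MTT assay, with a stated time of 24 h; a higher number here means a weaker inhibitor, a lower number a stronger inhibitor:

Compound 1 `O=c1nc2ccc(Br)cn2cc1Cc1ccc(Br)cc1`: > 1000000 nM (a limit)
Compound 2 `O=c1nc2ccccn2cc1Cc1ccc(F)cc1C(F)(F)F`: 804000 nM
Compound 3 `O=c1nc2ccc(Br)cn2cc1Cc1cccc(Oc2nc(Cl)c(Cl)cc2Cl)c1`: > 1000000 nM (a limit)

Among the measured compounds shown here, the value for compound 2, 804000 nM, is the only true number in the set. Compound 1 reports only a limit, > 1000000 nM. Compound 3 also reports only a limit, > 1000000 nM. The remaining evidence therefore comes down to the limit of > 1000000 nM in this assay, at which 2 of the 3 values shown sit.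

Compound 4 `O=c1nc2ccc(Cl)cn2cc1Cc1ccc(F)cc1C(F)(F)F` differs from compound 2 by a single change on the shared core: chloro in place of hydrogen on an aromatic carbon, two atoms from the ring nitrogen (chloro in place of hydrogen on an aromatic carbon). For the measured compounds named here, no measured pair differs in one place, so the data give no direct reading of this change. No shift beyond the usual scatter is expected in this assay, in either direction. The expected step is a 1.1-fold lower number from compound 2 to compound 4 (0.03 log units; within the scatter). This expectation rests on compound 2 at 804000 nM. A result reported only as a limit remains a real possibility for compound 4. For compound 4 the estimated half-maximal inhibitory concentration is 750000 nM, with an expected range of 350000 nM to 1000000 nM.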

Compound 4, half-maximal inhibitory concentration: > 1000000 nM
Compound 4 was reported as a limit; the forecaster's own chance of this, stated with the estimate: 40%; middle value at least 1.3-fold (0.12 log units) from the limit.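

Chloro in place of hydrogen on an aromatic carbon, two atoms from the ring nitrogen, gives the first comparison in the series that differs in one place: in this assay the step reads an at least 1.2-fold higher number from compound 2 to compound 4 (0.09 log units; that floor lies within the scatter). Among the compounds shown here, compound 4 is reported only as a limit, so the step has a floor and no true size, and that floor does not separate the two compounds beyond the usual scatter; still, this change at this position gives no sign of a lower number, which the earlier compounds could not show. With this result, the readout of the series rests mostly on a single ceiling: the limit of > 1000000 nM in this assay, at which 3 of the 4 values shown sit.

On these data alone, how far compound 4 lies beyond its limit stays open, as does the true size of the step. Also open, as far as these compounds go, is whether a different group at this same position, such as an amine or a carboxylic acid, would give a true number in this assay rather than another limit.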